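Cyclohexyl in place of cyclobutyl on an amide-type nitrogen

The source may hold more compounds than are shown below. What is called first, only, known or untested is meant among the compounds shown, and "the series" means these compounds.

Compound 1 `O=C(O)c1cc(-c2cccc(COc3ccc4c(c3)CN(C3CCC3)C4=O)c2)ccc1Cl` carries a cyclobutyl on an amide-type nitrogen in a ring. In an ADME assay on a cell-free system (plasma, Rattus norvegicus), with a stated time of 60 min (a lower number here means that less of the compound is left, a higher number that more of the compound is left), compound 1 gives 100% and compound 2 `O=C(O)c1cc(-c2cccc(COc3ccc4c(c3)CCN(C3CCCC3)C4=O)c2)ccc1Cl` gives 100% at the same reading. Among the measured compounds shown here, the two values are level, within the scatter of each other, so compound 1 stands at the same place as the only other measured compound. For the measured compounds named here, no step between measured compounds differing in one place is available, so the size of a change at this nitrogen has not been observed directly.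

Compound 3 `O=C(O)c1cc(-c2cccc(COc3ccc4c(c3)CN(C3CCCCC3)C4=O)c2)ccc1Cl` keeps the core of compound 1 and has cyclohexyl in place of cyclobutyl on the same nitrogen cyclohexyl in place of cyclobutyl on an amide-type nitrogen in a ring as its only difference. Both groups are non-aromatic rings of carbon only, with no net charge. Both measured compounds read the same in this assay and neither shows any loss, with compound 1 at 100% as the starting point. The expected result is a number 2 percentage points lower from compound 1 to compound 3 (within the scatter) as an estimate, which means no change beyond the scatter. For compound 3 the estimated value is 98% with an expected range from 88% to 104% in this measurement.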

Compound 3, percent of the compound remaining: 99%
Compound 3: middle estimate off by 1 percentage points, on the low side; the range from low to high includes it.
By their numbers in this assay, from the lowest: compounds 3, 1 and 2 (each within the scatter of the next).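

In this assay, among the compounds shown here, cyclohexyl in place of cyclobutyl on the amide-type nitrogen in a ring gives a number 1 percentage points lower from compound 1 to compound 3 (within the scatter), a directly observed step at this position that the earlier compounds did not offer. On the core of compound 1, a six-membered non-aromatic ring of carbon only therefore reads the same as a four-membered one, so this enlargement of the ring on the nitrogen leaves the read-out within the scatter. Nothing available bears on why this substitution leaves the reading where it stands.

Still open, as far as these compounds go, is how this assay would read with a group of another kind on this nitrogen, such as a phenyl ring, an open butyl chain or a piperidine ring with its amine. Also open, from the compounds shown here alone, is how it would read for a methyl ester in place of the carboxylic acid, and whether the same swap of cyclobutyl for cyclohexyl would give a similar step on a different core.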